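Benzyloxy versus propoxy on the coumarin hydrazide

This account rests on a few compounds, and the source may have more. Where it says the series, first, only, none or still open, it means among the compounds named here.

Measured so far in a functional assay on HCT-116 cells (Homo sapiens) for cytotoxicity, read by MTT assay, with a stated time of 72 h; a higher number here means a weaker inhibitor, a lower number a stronger inhibitor:
- compound 1, `O=C(NCCO)c1cc2ccc(OCc3ccccc3)cc2oc1=O`: 18700 nM
- compound 2, `O=C(Nc1ccccc1)c1cc2ccc(OCc3ccccc3)cc2oc1=O`: a limit, > 100000 nM
- compound 3, `CCCOc1ccc2cc(C(=O)NN)c(=O)oc2c1`: 69800 nM

Compound 3 gives the highest of the two numbers; its nearest neighbour is compound 1, whose value is lower by a clear margin. The value of compound 2 is a limit of the assay and not a number: the limit of > 100000 nM in this assay, at which 1 of the 3 values shown sits.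

Compound 4, `NNC(=O)c1cc2ccc(OCc3ccccc3)cc2oc1=O`, differs from compound 3 in one place: phenyl in place of ethyl on a saturated chain carbon bound to an oxygen on an aromatic ring. Among the measured compounds shown here, the only step measured within the set is an at least 5.3-fold higher number from compound 1 to compound 2 (0.72 log units; beyond the scatter), which changes the amide substituent, not the ether chain, so it does not bear on the present change. For the measured compounds named here, no pair among compounds 1 to 3 isolates the ether substituent alone; compounds 1 and 3 differ at two sites, so their gap cannot be attributed to either one.

Going by the values given here, with no step measured on this position, the expectation for compound 4 is a number close to that of compound 3, with wide uncertainty on both sides. The estimated step of a 1.6-fold lower number from compound 3 to compound 4 (0.19 log units; within the scatter) is expected to lie within or near the scatter. Compound 4 is estimated at 45000 nM, within 10000 nM to 150000 nM.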

Compound 4, half-maximal inhibitory concentration: > 100000 nM
Compound 4 ended at the assay's limit; the forecaster's own chance of this, stated with the estimate: 30%; middle value at least 2.2-fold (0.34 log units) from the limit.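

In this assay, from the compounds shown here alone, going from propyl to benzyl on the ether of the hydrazide gives an at least 1.4-fold higher number from compound 3 to compound 4 (0.15 log units; that floor lies within the scatter), so this change shows no gain at this position, and its true size remains unknown. With benzyl held fixed, changing the 2-hydroxyethyl amide into the hydrazide gives an at least 5.3-fold higher number from compound 1 to compound 4 (0.72 log units; beyond the scatter), which leaves compound 1 as the only benzyl compound shown with a value that is a number rather than a limit. The values of compound 2 and compound 4 are both limits, and the step between them cannot be read: the limit of > 100000 nM in this assay, at which 2 of the 4 values shown sit.

Going by these compounds, how far benzyl weakens the hydrazide, if it does at all, remains open, as does whether the amide substituent would behave the same way with propyl on the ether. A butyl chain in place of propyl would test chain length at this position without a ring, and a morpholine or a carboxylic acid at the end of the 2-hydroxyethyl chain would extend the one amide substituent that gives a readable value with benzyl.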